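Swapping the Pyridin-3-yl Arm for Thiophen-2-yl

This account rests on a few compounds, and the source may have more. Where it says the series, first, only, none or still open, it means among the compounds named here.

Compound 1 `Cc1ccc(-c2ccnc(Nc3ccc4c(c3)c(/C=C3/C(=O)Nc5ccccc53)cn4C)n2)cc1`: > 100000 nM (a limit of the assay, not a number)
Compound 2 `Cn1cc(/C=C2/C(=O)Nc3ccccc32)c2cc(Nc3nccc(-c4cccnc4)n3)ccc21`: 46600 nM

Both were tested in a functional assay on MCF7 cells (Homo sapiens) for cytotoxicity, read by MTT assay, with a stated time of 48 h; a lower number here means a stronger inhibitor, a higher number a weaker inhibitor. Compound 2 gives the only plain number shown; the other value is the limit (the limit of > 100000 nM in this assay, at which 1 of the 2 values shown sits). For the measured compounds named here, the one measured step, an at least 2.1-fold lower number from compound 1 to compound 2 (0.33 log units; beyond the scatter), lowered the number. Compound 3 `Cn1cc(/C=C2/C(=O)Nc3ccccc32)c2cc(Nc3nccc(-c4cccs4)n3)ccc21` carries the change (thiophen-2-yl in place of pyridin-3-yl on an aromatic carbon). Going by the values given here, that step is the only one bearing on this change, and it points the opposite way: taking the pyridin-3-yl out again is expected to raise the number, possibly back toward the limit. Compound 3 is therefore estimated at 75000 nM, within 30000 nM to 180000 nM. This expectation amounts to the step of a 1.6-fold higher number from compound 2 to compound 3 (0.21 log units; within the scatter).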

Compound 3, half-maximal inhibitory concentration: 30800 nM
Compound 3: middle estimate off by 2.4-fold (0.39 log units), on the high side; measured number inside the range.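

In this assay, the two hetero rings are not separated at this position, whether five-membered with sulfur or six-membered with nitrogen: a 1.5-fold lower number from compound 2 to compound 3 (0.18 log units; within the scatter). Replacing 4-methylphenyl with thiophen-2-yl gives an at least 3.2-fold lower number from compound 1 to compound 3 (0.51 log units; beyond the scatter), so both hetero rings now stand apart from 4-methylphenyl. That second step has only a bound, since compound 1 gives a limit and not a number: the limit of > 100000 nM in this assay, at which 1 of the 3 values shown sits.

As far as these compounds go, it remains open whether plain phenyl, or a thiophen-2-yl carrying an amine or a carboxylic acid, would fall with the hetero rings or with 4-methylphenyl. The compounds shown also leave open whether any group here brings a much lower number.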